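Carboxy in place of hydroxy: from compound 2 to compound 3

The source may hold more compounds than are shown below. What is called first, only, known or untested is meant among the compounds shown, and "the series" means these compounds.

Compound 2 `CCOc1ccc2nc(C(=O)Nc3c(F)cc(-c4cccc(F)c4)cc3F)c(C)c(O)c2c1` is the lower of the two measured compounds in a functional assay on Hep 3B2 cells (Homo sapiens) for antiproliferative activity, read by MTT assay, with a stated time of 24 h, tested at 33.33 ug/mL (a higher number here means a stronger effect of the compound at the concentration tested, a lower number a weaker effect), where compound 2 gives 11.2%. Among the measured compounds shown here, compound 1 `Cc1c(C(=O)Nc2c(F)cc(-c3cccc(F)c3)cc2F)nc2ccc(F)cc2c1O` gives 41.2%; the only measured step, a number 30 percentage points lower from compound 1 to compound 2 (beyond the scatter), concerns ethoxy in place of fluoro on an aromatic carbon. Compound 3 `CCOc1ccc2nc(C(=O)Nc3c(F)cc(-c4cccc(F)c4)cc3F)c(C)c(C(=O)O)c2c1` differs from compound 2 by carboxy in place of hydroxy on an aromatic carbon. For the measured compounds named here, no measured step bears on carboxy in place of hydroxy, so no shift beyond the scatter is expected. Compound 3 is therefore expected to give 12%, between 0% and 35%. The expected step of a number 0.8 percentage points higher from compound 2 to compound 3 (within the scatter) is estimated to stay within the scatter.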

Compound 3, a percentage reported as inhibition, at one concentration (the size of the read-out at that concentration, not a potency): 38.7%
Compound 3: middle estimate off by 26.7 percentage points, on the low side, and the stated range ends below it.
By their numbers in this assay, from the lowest: compound 2; then compounds 3 and 1 (each within the scatter of the next).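

At this position, opposite the ring nitrogen and ortho to a methyl group, the series responds to the group present: in this assay, carboxy in place of hydroxy gives a number 27.5 percentage points higher from compound 2 to compound 3 (beyond the scatter). The low number of compound 2 therefore does not follow from the ethoxy group alone, since that group is present in both compounds of this step. Nothing available accounts for this rise. Still open, from the compounds shown here alone, is whether a methyl ester or a primary amide at this position would keep the gain. Also open, going by these compounds, is whether carboxy gives the same step with fluoro in place of ethoxy.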